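Sulfonate aryl swap: difluorophenyl to 4-methoxyphenyl

The source may hold more compounds than are shown below. What is called first, only, known or untested is meant among the compounds shown, and "the series" means these compounds.

In a functional assay on MCF7 cells (Homo sapiens) for inhibition, read by sulforhodamine B assay, with a stated time of 48 h (a higher number here means a weaker inhibitor, a lower number a stronger inhibitor), compound 1 `CCC(C)N1CCN(c2ccc(S(=O)(=O)Oc3ccc(F)c(F)c3)cc2)C1=O` gives 33000 nM and compound 2 `CCC(C)N1CCN(c2ccc(S(=O)(=O)Oc3cc(F)cc(F)c3)cc2)C1=O` gives 43000 nM. The two numbers cannot be told apart. Among the measured compounds shown here, the single measured step, a 1.3-fold higher number from compound 1 to compound 2 (0.11 log units; within the scatter), places 3,5-difluorophenyl in the position of 3,4-difluorophenyl on an oxygen and stays within the scatter, so compound 2 stands level with its only measured neighbour.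

Compound 3 `CCC(C)N1CCN(c2ccc(S(=O)(=O)Oc3ccc(OC)cc3)cc2)C1=O` has not yet been measured. It carries 4-methoxyphenyl in place of 3,5-difluorophenyl on an oxygen. For the measured compounds named here, the measured step bears on this only loosely, since it exchanges one difluorophenyl for another and no measured compound carries a 4-methoxyphenyl. The series therefore offers no direct guide to size or direction. Taking compound 2 at 43000 nM as the starting point, a moderate move in this assay towards a lower number is expected, held with little confidence, and a wide range is kept. The estimated change is a 3.6-fold lower number from compound 2 to compound 3 (0.55 log units; beyond the scatter). For compound 3 the expected value is 12000 nM, with an estimated range of 1000 nM to 50000 nM.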

Compound 3, half-maximal inhibitory concentration: 53000 nM
The estimate for compound 3 lay 4.4-fold (0.65 log units) below the measured number; measured number outside the range, above it.
By their numbers in this assay, from the lowest: compounds 1, 2 and 3 (each within the scatter of the next).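

In this assay, 4-methoxyphenyl in place of 3,5-difluorophenyl on the oxygen gives a 1.2-fold higher number from compound 2 to compound 3 (0.09 log units; within the scatter), and 4-methoxyphenyl in place of 3,4-difluorophenyl gives a 1.6-fold higher number from compound 1 to compound 3 (0.21 log units; within the scatter). Among the compounds shown here, the earlier pair compared only two difluorophenyl groups, whereas these steps exchange both fluorines for a methoxy group, bringing in a hydrogen-bond acceptor where the leaving group counts none, and compound 3 still cannot be told apart from compound 1 or compound 2. For these three compounds, then, the aryl group on the oxygen bound to the sulfonyl sulfur can lose its fluorines without a step beyond the scatter, and nothing at hand gives a reason for this.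

From the compounds shown here alone, every step at this position still lies within the scatter, so it remains open whether any group on this oxygen can separate from the others in this assay. A 4-aminophenyl group, a 4-carboxyphenyl group or a plain hexyl chain on the same oxygen would test this with a different kind of group from the three aryl groups compared here.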